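The source may hold more compounds than are shown below. What is called first, only, known or untested is meant among the compounds shown, and "the series" means these compounds.

Measured in (a functional assay on Bel-7402 cells (Homo sapiens) for cytotoxicity, read by MTT assay; on this read-out lower numbers stand for stronger inhibition and higher numbers for weaker inhibition):
- compound 1 (`CC1(C)C2CCC1(C)C(OC(=O)/C=C/c1ccc(O)c(O)c1[N+](=O)[O-])C2`) gives (28700 nM)
- compound 2 (`O=C(/C=C/c1cc(O)c(O)c([N+](=O)[O-])c1)OCCc1ccccc1`) gives (59700 nM)

Only these two numbers are available so far. Compound 2 holds the higher one (59700 nM), which makes it the weaker inhibitor of the pair. Its gap to compound 1 (28700 nM) lies beyond the usual scatter of repeated measurements.

Compound 3 (`COc1cc(/C=C/C(=O)OCCc2ccccc2)cc([N+](=O)[O-])c1O`) has not yet been measured in (this assay). It differs from compound 2 at a single place (methyl in place of hydrogen on an oxygen on an aromatic ring), with methyl in place of hydrogen on an oxygen on an aromatic ring, so that a hydroxy becomes a methoxy. Going by the values given here, no measured pair in this small set shows this change, and the expectation therefore rests on very little. A modest move toward a higher number seems more likely than a move toward a lower one, and a result within the scatter would not be surprising. The expected step is (a 1.4-fold higher number from compound 2 to compound 3 (0.15 log units; within the scatter)), a small loss of inhibition. Compound 3 is estimated at (85000 nM), with an expected range from (35000 nM) to (200000 nM).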

Compound 3, half-maximal inhibitory concentration: > 300000 nM
Compound 3 ended at the assay's limit; the forecaster's own chance of this, stated with the estimate: 15%; at least 3.5-fold (0.54 log units) between middle value and limit.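

In this assay, methyl in place of hydrogen on an oxygen on an aromatic ring, turning a hydroxy into a methoxy, gives an at least 5.0-fold higher number from compound 2 to compound 3 (0.70 log units; beyond the scatter). Going by these compounds alone, this is the first step in the set that changes a single place, and it shows that this oxygen is not indifferent to what it carries: the change runs toward weaker inhibition, by more than the usual scatter. Compound 3 stands at a limit of the assay, so the step sets only a minimum for the loss and its full size remains unknown: the limit of > 300000 nM in this assay, at which 1 of the 3 values shown sits.

The compounds shown leave open whether the loss follows from removing the hydrogen or from adding the methyl, a question that an ethoxy, a longer chain on the same oxygen or an amine in place of the hydroxy would bear on. As far as these compounds go, it also remains open whether the same change would weaken inhibition on the core of compound 1, and whether the remaining hydroxy of compound 3 responds to a methyl in the same way.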